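Same Atoms, Joined Differently: What to Expect for Compound 4

The source may hold more compounds than are shown below. What is called first, only, known or untested is meant among the compounds shown, and "the series" means these compounds.

Measured so far in an assay on isolated protein for inhibition of Fatty-acid amide hydrolase 1 (Homo sapiens), with a stated time of 60 min; on this read-out lower numbers stand for stronger inhibition and higher numbers for weaker inhibition:
- compound 1, `Cc1nc2cc(NC(=O)N3CCN(Cc4cccc(Oc5ccc(Cl)cc5)c4)CC3)ccc2o1`, gives 7.7 nM
- compound 2, `O=C(Nc1noc2ccncc12)N1CCN(Cc2cccc(Oc3ccc(Cl)cc3)c2)CC1`, gives 180 nM
- compound 3, `O=C(Nc1cccn2ccnc12)N1CCN(Cc2cccc(Oc3ccc(Cl)cc3)c2)CC1`, gives 310 nM

Compound 3 has the highest number of the three in this assay. Its gap to compound 2 is small, a 1.7-fold higher number from compound 2 to compound 3 (0.24 log units; within the scatter), whereas compound 1 sits far lower, a 40-fold higher number from compound 1 to compound 3 (1.60 log units; beyond the scatter).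

Compound 4, `O=C(Nc1ccc2nccn2c1)N1CCN(Cc2cccc(Oc3ccc(Cl)cc3)c2)CC1`, has the same atoms as compound 3 but joined differently: a group of 9 heavy atoms (7 carbon, 2 nitrogen; one five-membered aromatic ring with 2 hetero atoms, one six-membered aromatic ring with 1 hetero atom) in place of a group of 9 heavy atoms (7 carbon, 2 nitrogen; one five-membered aromatic ring with 2 hetero atoms, one six-membered aromatic ring with 1 hetero atom), on an amide-type nitrogen. Among the compounds with values here, no measured step involves such a rearrangement directly. The closest guide is the step from compound 2 to compound 3, where one bicyclic group carrying a six-membered ring with one hetero atom was swapped for another and the number barely moved, a 1.7-fold higher number from compound 2 to compound 3 (0.24 log units; within the scatter). Both of those groups lie far from the benzoxazole-type head of compound 1, as a 23-fold higher number from compound 1 to compound 2 (1.37 log units; beyond the scatter) and a 40-fold higher number from compound 1 to compound 3 (1.60 log units; beyond the scatter) show. The change from compound 3 to compound 4 keeps the same atom counts and ring types, so a step of no more than the usual scatter is expected in this assay, a 1.4-fold lower number from compound 3 to compound 4 (0.15 log units; within the scatter), with direction uncertain.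

Compound 4 is therefore expected to give about 220 nM in this assay, within a range of 70 nM to 700 nM.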

Compound 4, half-maximal inhibitory concentration: 100 nM
Compound 4: the middle estimate sits 2.2-fold (0.34 log units) above what was measured, and the stated range covers the measured number.
By their numbers in this assay, from the lowest: compound 1; then compounds 4, 2 and 3 (each within the scatter of the next, the first and the last beyond it).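

In this assay, within the data shown here, the two groups on the amide-type nitrogen have the same atoms and ring types and differ only in how they are joined, yet the number still moves beyond the scatter (a 3.1-fold lower number from compound 3 to compound 4 (0.49 log units; beyond the scatter)), something the earlier steps could not show because each of them also changed the atoms. The rearrangement does not close the large gap to the group with a six-membered aromatic ring of carbon only (a 13-fold higher number from compound 1 to compound 4 (1.11 log units; beyond the scatter)), while the step to the oxygen-containing group of the same size stays within the scatter (a 1.8-fold lower number from compound 2 to compound 4 (0.26 log units; within the scatter)). Nothing available explains why the way the rings are joined matters here.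

The compounds shown leave open whether the gap to compound 1 comes from its carbon-only six-membered ring, its methyl group or the way its group is joined, since these differences always occur together. They also leave open how a fluorine or a nitrile on the group in compound 4 would shift the number.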